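The compounds below may be only part of what the source reports. "The series", "measured", "known", "first", "only" and "open" are said of these compounds alone.

Two compounds of this series have numbers in a functional assay on LNCaP cells (Homo sapiens) for antiproliferative activity; on this read-out higher numbers stand for weaker inhibition and lower numbers for stronger inhibition. Compound 1 `CNC(=O)C[C@@H]1C[C@@H](c2ccc(Cl)c(Cl)c2)[C@H](NC(=O)c2cc(-c3c(Cl)cnn3C)c(Cl)o2)CN1` gives 40 nM, and compound 2 `Cn1ncc(Cl)c1-c1cc(C(=O)N[C@@H]2CN[C@H](CCNS(C)(=O)=O)C[C@H]2c2ccc(F)c(F)c2)oc1Cl` gives 50 nM; the two values lie within the scatter of each other, so neither stands apart. Compound 3 `Cn1ncc(Cl)c1-c1cc(C(=O)N[C@@H]2CN[C@H](CCCO)C[C@H]2c2ccc(Cl)c(Cl)c2)oc1Cl` is not yet measured; it differs from compound 1 by 2-hydroxyethyl in place of methylcarbamoyl on a saturated chain carbon bound to a saturated ring carbon. Among the measured compounds shown here, no measured pair isolates this change, so the step of a 1.8-fold higher number from compound 1 to compound 3 (0.24 log units; within the scatter) is expected to be small, leaning towards a somewhat higher number. Compound 3 is estimated at 70 nM, with a range from 25 nM to 200 nM.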

Compound 3, half-maximal inhibitory concentration: 210 nM
The estimate for compound 3 lay 3.0-fold (0.48 log units) below the measured number; measured number above the stated range.
By their numbers in this assay, from the lowest: compounds 1 and 2 (each within the scatter of the next); then compound 3.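

On this assay this position is not indifferent to the group it carries: 2-hydroxyethyl in place of methylcarbamoyl on a saturated chain carbon bound to a saturated ring carbon gives a 5.3-fold higher number from compound 1 to compound 3 (0.72 log units; beyond the scatter) and takes the number clearly out of the scatter. The two groups have equal hydrogen-bond donor and acceptor counts, so these counts alone do not set the number here. Nothing at hand explains the step.

From the compounds shown here alone, whether the loss follows from giving up the carbonyl or the methylamino part remains open, since the change replaces the whole group. A carboxylic acid, a primary amide or an amine on this chain could separate these possibilities.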